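This account rests on a few compounds, and the source may have more. Where it says the series, first, only, none or still open, it means among the compounds named here.

Compound 1 `COc1cc(/C=C/C(=O)C2=C(/C=C/c3ccc(O)c(OC)c3)NC(=O)NC2c2ccc(N(C)C)cc2)ccc1O` was tested in a functional assay, with a stated time of 20 min, tested at 2 uM (on this read-out higher numbers stand for a stronger effect at the one concentration tested and lower numbers for a weaker effect), where compound 1 gives 17.9%. Compound 2 `COc1cc(/C=C/C(=O)C2=C(/C=C/c3ccc(O)c(OC)c3)NC(=O)NC2c2c(Cl)cccc2Cl)ccc1O` differs from compound 1 in one place: 2,6-dichlorophenyl in place of 4-(dimethylamino)phenyl on a saturated ring carbon. In this assay compound 2 gives 11.2%; the change made a number 6.7 percentage points lower from compound 1 to compound 2 (within the scatter), so the two values cannot be ordered against each other. Compound 3 `COc1cc(/C=C/C(=O)C2=C(/C=C/c3ccc(O)c(OC)c3)NC(=S)NC2c2ccc(N(C)C)cc2)ccc1O` carries the same groups on the saturated ring carbon as compound 1 but has a different core; the difference between the two cores is not broken down here. In this assay compound 3 gives 30.2%, the highest of the three numbers, beyond the scatter from both compound 1 and compound 2.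

Compound 4 `COc1cc(/C=C/C(=O)C2=C(/C=C/c3ccc(O)c(OC)c3)NC(=S)NC2c2c(Cl)cccc2Cl)ccc1O` has not yet been measured. It differs from compound 3 in one place: 2,6-dichlorophenyl in place of 4-(dimethylamino)phenyl on a saturated ring carbon. This is the same change, at the same place, as the one from compound 1 to compound 2, and it occurs twice among these four compounds. Because the earlier step of a number 6.7 percentage points lower from compound 1 to compound 2 (within the scatter) lay within the scatter, the step from the thione pair is expected to be small as well. The step expected in this assay is a number 6.2 percentage points lower from compound 3 to compound 4 (within the scatter), which rests on the earlier pair only. Compound 4 is therefore estimated in this assay at 24%, most likely between 12% and 36%.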

Compound 4, a percentage reported as activity, at one concentration (the size of the read-out at that concentration, not a potency): 17.7%
For compound 4 the middle estimate is 6.3 percentage points above the measured one, within the range that was stated.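

In this assay, putting 2,6-dichlorophenyl in place of 4-(dimethylamino)phenyl on the saturated ring carbon of the core of compound 3 gives a number 12.5 percentage points lower from compound 3 to compound 4 (beyond the scatter), and this step cannot be told apart in size from the same change on the core of compound 1: the same change on two cores in this assay, a number 6.7 percentage points lower (within the scatter) from compound 1 to compound 2 and a number 12.5 percentage points lower (beyond the scatter) from compound 3 to compound 4, 5.8 percentage points apart, within the scatter of two such steps. Within these two pairs, then, the size of the change carries from one core to the other without a difference that can be resolved, although only the step on the core of compound 3 lies beyond the scatter, so the earlier pair does not by itself fix a direction. This does not show that the two steps are identical, as a real gap smaller than the scatter would go unseen, and it does not show that the change would behave alike on any core other than these two.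

The compounds shown leave open how a different group on the saturated ring carbon, such as an unsubstituted phenyl, a phenyl bearing a carboxylic acid or a longer alkyl chain, would fare on either core. They also leave open whether the same comparison would hold at other concentrations, as each compound is represented here by a single read-out at one concentration, which is not a potency.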